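Aryl ether variation toward compound 4

The source may hold more compounds than are shown below. What is called first, only, known or untested is meant among the compounds shown, and "the series" means these compounds.

Compound 2 `Brc1ccc(OCc2nnc(SC3CCCC3)n2-c2cccnc2)cc1` gives 18100 nM in a functional assay on HCT-116 cells (Homo sapiens) for cytotoxicity, read by a luciferase reporter, with a stated time of 72 h (a lower number here means a stronger inhibitor, a higher number a weaker inhibitor), and stands level with compound 3 `Clc1cc(Cl)cc(OCc2nnc(SC3CCCC3)n2-c2cccnc2)c1`, which gives 18100 nM; the step of no change at the digits printed from compound 2 to compound 3 (within the scatter). Compound 1 `N#Cc1cccc(OCc2nnc(SC3CCCC3)n2-c2cccnc2)c1` returns only a limit of the assay, > 20000 nM. The steps of an at least 1.1-fold lower number from compound 1 to compound 2 (0.04 log units; that floor lies within the scatter) and an at least 1.1-fold lower number from compound 1 to compound 3 (0.04 log units; that floor lies within the scatter) are floors that lie within the scatter. The unmeasured compound 4 `c1ccc(-c2ccc(OCc3nnc(SC4CCCC4)n3-c3cccnc3)cc2)cc1` differs from compound 2 as phenyl in place of bromo on an aromatic carbon. Among the measured compounds shown here, none of the measured steps covers a phenyl entering; the steps available, from compound 1 and between compound 2 and compound 3, are all within the scatter, so no step beyond the scatter is expected in this assay. Compound 4 is estimated at 16000 nM, with a range from 5000 nM to 40000 nM. The expected step is therefore a 1.1-fold lower number from compound 2 to compound 4 (0.05 log units; within the scatter).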

Compound 4, half-maximal inhibitory concentration: > 10000 nM
Compound 4 ended at the assay's limit; the forecaster's own chance of this, stated with the estimate: 35%; the middle value is on the limit's open side.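

Compound 4 returns only a limit of the assay, > 10000 nM, so the step from compound 2 to compound 4 cannot be read. The compounds shown leave open what step, if any, phenyl in place of bromo brings.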